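Methyl in place of chloro: compound 1 to compound 4

This account rests on a few compounds, and the source may have more. Where it says the series, first, only, none or still open, it means among the compounds named here.

Measured in a functional assay on NCI/ADR-RES cells (Homo sapiens) for inhibition, read by sulforhodamine B assay, with a stated time of 48 h; on this read-out lower numbers stand for stronger inhibition of growth and higher numbers for weaker inhibition of growth:
- compound 1 `S=C(N/N=C/c1cccs1)Nc1ccc(Cl)cc1`: 2800 nM
- compound 2 `S=C(N/N=C/c1cccs1)Nc1cccnc1`: > 100000 nM (a limit of the assay)
- compound 3 `S=C(N/N=C/c1cccs1)Nc1cccc2ccccc12`: 6600 nM

Compound 1 holds the lower of the two actual numbers at 2800 nM, and compound 3 at 6600 nM lies beyond the scatter from it. For compound 2, > 100000 nM is a limit and not a number.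

The next compound, compound 4 `Cc1ccc(NC(=S)N/N=C/c2cccs2)cc1`, carries methyl in place of chloro on an aromatic carbon, para to a large group (methyl in place of chloro on an aromatic carbon). Among the measured compounds shown here, no measured pair shows this change directly. The expectation therefore rests on compound 1 at 2800 nM and compound 3 at 6600 nM, which both give numbers. In this assay a small move toward a higher number is expected, close to the scatter in size. The estimated change is a 1.4-fold higher number from compound 1 to compound 4 (0.15 log units; within the scatter). The expected value for compound 4 is 4000 nM, with an estimated range of 1500 nM to 12000 nM.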

Compound 4, concentration for 50% growth inhibition: 4800 nM
Compound 4: middle estimate off by 1.2-fold (0.08 log units), on the low side, within the range that was stated.
By their numbers in this assay, from the lowest: compounds 1, 4 and 3 (each within the scatter of the next, the first and the last beyond it). At a limit, above all of these: compound 2.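

Among the compounds shown here, the step of a 1.7-fold higher number from compound 1 to compound 4 (0.23 log units; within the scatter) is the first direct reading of a single change on the six-membered aromatic ring, para to a large group. In this assay, compound 1 and compound 4 cannot be told apart, so at this place methyl serves as well as chloro, and growth inhibition does not depend on chlorine being there. This holds for these two groups only, and nothing shown gives a cause for the step.

From the compounds shown here alone, how an amine, a carboxylic acid or a longer chain such as butyl would read at this place remains open. Also open, going by these compounds, is whether methyl in place of chloro on another aromatic carbon of this ring would read the same way.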